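Notes on the chlorophenyl series: from compound 2 to compound 3

The source may hold more compounds than are shown below. What is called first, only, known or untested is meant among the compounds shown, and "the series" means these compounds.

Measured so far in an assay on Sf9 cells for inhibition of protein deacetylase HDAC6 (Homo sapiens), read by fluorescence, with a stated time of 40 min, tested at 100 nM; a lower number here means less inhibition, a higher number more inhibition at the concentration tested (going by the name of the read-out):
compound 1, `O=C(NO)c1ccc(NCc2nc(-c3cccc4cnccc34)nn2-c2ccccc2)cc1`, gives 40.2%
compound 2, `O=C(NO)c1ccc(NCc2nc(-c3cccc(Cl)c3)nn2-c2ccccc2)cc1`, gives 61.2%

Within the data shown here, compound 2 stands highest of the two numbers in this assay; its only neighbour is compound 1, whose number is lower by the step of a number 21 percentage points higher from compound 1 to compound 2 (beyond the scatter), a modest step that lies beyond the scatter and rests on 3-chlorophenyl in place of isoquinolin-5-yl on an aromatic carbon.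

Compound 3, `O=C(NO)c1ccc(NCc2nc(-c3ccc(Cl)cc3)nn2-c2ccccc2)cc1`, is not yet measured. It differs from compound 2 as follows: 4-chlorophenyl in place of 3-chlorophenyl on an aromatic carbon. The two compounds hold the same atoms, joined differently.

Among the measured compounds shown here, no measured step bears on this change. For the measured compounds named here, the single step recorded, from compound 1 to compound 2, concerns a different replacement of the whole aryl group and says nothing about where the chlorine sits on the chlorophenyl. With nothing in the series pointing either way, no step beyond the scatter is expected in this assay, and the number for compound 3 is expected to sit close to that of compound 2.

Compound 3 is therefore estimated at 58%, with a range from 40% to 76%; this means an expected step of a number 3.2 percentage points lower from compound 2 to compound 3 (within the scatter).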

Compound 3, a percentage reported as inhibition, at one concentration (the size of the read-out at that concentration, not a potency): 67.2%
Compound 3: middle estimate off by 9.2 percentage points, on the low side, and the stated range covers the measured number.
By their numbers in this assay, from the lowest: compound 1; then compounds 2 and 3 (each within the scatter of the next).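

In this assay, placing 4-chlorophenyl in place of 3-chlorophenyl on this aromatic carbon of the five-membered ring gives a number 6 percentage points higher from compound 2 to compound 3 (within the scatter), so the two chlorine placements cannot be told apart in this read-out. Set against the isoquinolin-5-yl group, the 4-chlorophenyl group gives a number 27 percentage points higher from compound 1 to compound 3 (beyond the scatter), which stands with the earlier a number 21 percentage points higher from compound 1 to compound 2 (beyond the scatter) and shows that the difference from compound 1 holds for both chlorophenyl groups. Nothing at hand accounts for these numbers or for the lack of separation between the two chlorophenyl groups.

Whether the chlorine matters at all remains open, as the compounds shown do not include an unsubstituted phenyl, a 2-chlorophenyl or a 4-methoxyphenyl group at this carbon. On these data alone, the phenyl group on the ring atom two ring bonds away is also constant throughout, so it is unknown whether the same picture would hold with a pyridyl or cyclohexyl group there, and each number, taken at a single concentration, is not a potency.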